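A few compounds are considered here, and "the series" means these few. Any claim that something is new, unique, unknown or untested is made for them only; others in the source may bear on it.

Compound 1 `Fc1ccc(-c2nn3c(NC4CCCC4)nccc3c2-c2ccnc(NC3CCCC3)n2)cc1` is examined in an ADME assay on Vero cells (Chlorocebus sabaeus) for cytotoxicity (on this read-out lower numbers stand for higher toxicity in this test and higher numbers for lower toxicity in this test), where compound 1 gives only a limit of the assay, > 40000 nM. Compound 2 `Fc1ccc(-c2nn3c(N4CCCCC4)nccc3c2-c2ccnc(NC3CCCC3)n2)cc1` also gives only a limit in this assay, > 40000 nM. Compound 3 `CC(C)(C)Nc1nccc2c(-c3ccnc(NC4CCCC4)n3)c(-c3ccc(F)cc3)nn12` likewise gives only a limit in this assay, > 40000 nM. The steps a step that the two limits leave unreadable from compound 1 to compound 2, a step that the two limits leave unreadable from compound 1 to compound 3 and a step that the two limits leave unreadable from compound 2 to compound 3 thus cannot be sized, because of the limit of > 40000 nM in this assay, at which 3 of the 3 values shown sit. Compound 4 `COc1ccc(-c2nn3c(NC4CCCC4)nccc3c2-c2ccnc(NC3CCCC3)n2)cc1` differs from compound 1 by methoxy in place of fluoro on an aromatic carbon. Within the data shown here, none of the measured steps touches this position, and every measured value sits at the limit, so compound 4 is expected to remain at the limit too, with an expected step of a number no higher from compound 1 to compound 4 (the limit leaves the size open). Compound 4 is estimated at 40000 nM in this assay, between 20000 nM and 80000 nM.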

Compound 4, half-maximal cytotoxic concentration: > 40000 nM
Compound 4 gave a limit, no number (the forecaster's own chance of this, stated with the estimate: 85%); the middle value sits exactly at the limit.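

No step can be read between compound 1 and compound 4, because both give only a limit in this assay: the limit of > 40000 nM in this assay, at which 4 of the 4 values shown sit. The compounds shown leave open whether methoxy in place of fluoro changes cytotoxicity at all, and what any compound's actual value is.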